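The compounds below may be only part of what the source reports. "The series", "measured", "known", "first", "only" and "open" are said of these compounds alone.

Compound 1 `O=C(CSC(=S)N[C@H]1CCOC1=O)Nc1ccc(Cl)cc1` gives 76900 nM in a functional assay on MGC-803 cells (Homo sapiens) for cytotoxicity, read by MTT assay, with a stated time of 72 h; on this read-out lower numbers stand for stronger inhibition and higher numbers for weaker inhibition. Compound 2 `COc1ccc(NC(=O)CSC(=S)N[C@H]2CCOC2=O)cc1` gives 62100 nM in this assay. Compound 3 `O=C(CCl)Nc1ccc(C(=O)/C=C/c2cccc(Cl)c2)cc1` gives 2010 nM in this assay.

Compound 2 differs from compound 1 by methoxy in place of chloro on an aromatic carbon, and that step, a 1.2-fold lower number from compound 1 to compound 2 (0.09 log units; within the scatter), lies within the usual scatter. Compound 3 has the lowest number of the three and a different core; the difference between the two cores is not broken down here. Compound 4 `COc1cccc(/C=C/C(=O)c2ccc(NC(=O)CCl)cc2)c1` is related to compound 3 by methoxy in place of chloro on an aromatic carbon. This is the same kind of change as that from compound 1 to compound 2, but the place differs: there the group sits para to a large group, here meta to a large group. Since the earlier step was small, the step from compound 3 to compound 4 is expected to be small too, a 1.2-fold higher number from compound 3 to compound 4 (0.09 log units; within the scatter), resting on a 1.2-fold lower number from compound 1 to compound 2 (0.09 log units; within the scatter). Compound 4 is estimated at 2500 nM, expected between 1000 nM and 6000 nM.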

Compound 4, half-maximal inhibitory concentration: 2910 nM
Compound 4: the middle estimate sits 1.2-fold (0.07 log units) below what was measured; the measured number falls inside the stated range.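

Putting methoxy in place of chloro on the core of compound 3 gives a 1.4-fold higher number from compound 3 to compound 4 (0.16 log units; within the scatter). Set beside the earlier step, this small change stays small on both cores in this assay: the same change on two cores in this assay, a 1.2-fold lower number (0.09 log units; within the scatter) from compound 1 to compound 2 and a 1.4-fold higher number (0.16 log units; within the scatter) from compound 3 to compound 4, 1.8-fold (0.25 log units) apart, within the scatter of two such steps. Going by these compounds alone, this rests on only two pairs and one swap, and with both steps inside the scatter it shows no direction for the change, nor whether a larger step would carry across cores in the same way.

On these data alone, it remains open whether other groups in this place, such as an amine or a carboxylic acid, would move the number beyond the scatter. Also open, as far as these compounds go, is whether this same swap would stay small elsewhere on either core.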